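Adding Chloro to Compound 1: What Three Limits Allow

A few compounds are considered here, and "the series" means these few. Any claim that something is new, unique, unknown or untested is made for them only; others in the source may bear on it.

Compound 1 `COc1ccccc1C(=O)Nc1ccc(Sc2nc3ccccc3s2)cc1` was tested in an assay on isolated protein for inhibition of thiosulfate sulfurtransferase (Homo sapiens), with a stated time of 60 min, in the absence of a further agent; a lower number here means a stronger inhibitor, a higher number a weaker inhibitor. In this assay compound 1 gives > 100000 nM, which is a limit of the assay rather than a number. Two close relatives were measured alongside it. Compound 2 `O=C(Nc1ccc(Sc2nc3ccccc3s2)cc1)c1ccccc1O` carries hydrogen in place of methyl on an oxygen on an aromatic ring, and in this assay compound 2 gives > 100000 nM, again a limit. Compound 3 `O=C(Nc1ccc(Sc2nc3ccccc3s2)cc1)c1cccc(Br)c1O` carries 3-bromo-2-hydroxyphenyl in place of 2-methoxyphenyl on the carbonyl carbon, and in this assay compound 3 gives > 100000 nM, also a limit. Because the limit of > 100000 nM in this assay, at which 3 of the 3 values shown sit, the steps a step that the two limits leave unreadable from compound 1 to compound 2, a step that the two limits leave unreadable from compound 1 to compound 3 and a step that the two limits leave unreadable from compound 2 to compound 3 cannot be read in size. Compound 1 thus stands at the same limit as both of its measured relatives, with no order among them.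

Compound 4 `COc1ccccc1C(=O)Nc1ccc(Sc2nc3ccccc3s2)c(Cl)c1` differs from compound 1 by chloro in place of hydrogen on an aromatic carbon, on an aromatic carbon of a six-membered aromatic ring of carbon only, ortho to a large group and meta to a large group. Among the measured compounds shown here, none of the measured steps touches that ring, and all three end at the limit, so they give no direction for this change. Compound 4 is therefore expected to stay near the limit, with the step that the limit leaves unreadable from compound 1 to compound 4 expected to be small. The estimated value for compound 4 in this assay is 150000 nM, expected to fall between 40000 nM and 600000 nM.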

Compound 4, half-maximal inhibitory concentration: > 100000 nM
Compound 4: only a limit was reported; the forecaster's own chance of this, stated with the estimate: 85%; the middle value is on the limit's open side.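

In this assay compound 4 gives > 100000 nM, which is a limit and not a number. No size can be read for the change from compound 1 to compound 4, and no order can be set among the compounds: the limit of > 100000 nM in this assay, at which 4 of the 4 values shown sit. The compounds shown leave open how strongly any of them inhibits, and whether any of these changes affects inhibition at all.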